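The source may hold more compounds than are shown below. What is called first, only, known or untested is meant among the compounds shown, and "the series" means these compounds.

Measured so far in a physicochemical assay for solubility, at pH 7.4; a lower number here means a less soluble compound, a higher number a more soluble compound:
- compound 1 `Cc1cc(NC(=O)Nc2ccccc2F)c2ccccc2n1`: 3800 nM
- compound 2 `Cc1cc(NC(=O)Nc2ccccc2N)c2ccccc2n1`: 51800 nM
- compound 3 `Cc1cc(NC(=O)Nc2ccccc2C(C)(C)C)c2ccccc2n1`: 100 nM

Compound 3 stands lowest of the three numbers in this assay. Both steps that lead to it are large and in the same direction: a 38-fold lower number from compound 1 to compound 3 (1.58 log units; beyond the scatter) and a 520-fold lower number from compound 2 to compound 3 (2.71 log units; beyond the scatter). Against that, a 14-fold higher number from compound 1 to compound 2 (1.13 log units; beyond the scatter) is the only step not involving the tert-butyl group.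

Compound 4 `COc1ccccc1NC(=O)Nc1cc(C)nc2ccccc12` is the next step from compound 3: methoxy in place of tert-butyl on an aromatic carbon. Going by the values given here, no measured pair exchanges tert-butyl for methoxy, so the two steps into compound 3 are the only guide. Both show tert-butyl attached to a number far lower than either alternative, so for compound 4 a large step upward in this assay is expected, more probably toward the level of compound 1 than of compound 2. Compound 4 is therefore estimated at 3000 nM, range 800 nM to 12000 nM. For compound 4 the expected change is a 30-fold higher number from compound 3 to compound 4 (1.48 log units; beyond the scatter).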

Compound 4, solubility: 100 nM
For compound 4 the middle estimate is 30-fold (1.48 log units) above the measured one; measured number outside the range, below it.
By their numbers in this assay, from the lowest: compounds 3 and 4 (each within the scatter of the next); then compound 1; then compound 2.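

In this assay the low level at this aromatic carbon does not belong to tert-butyl alone: methoxy in place of tert-butyl gives no change at the digits printed from compound 3 to compound 4 (within the scatter), although methoxy is the smaller group and carries a hydrogen-bond acceptor. Methoxy in place of amino gives a 520-fold lower number from compound 2 to compound 4 (2.71 log units; beyond the scatter), and methoxy in place of fluoro gives a 38-fold lower number from compound 1 to compound 4 (1.58 log units; beyond the scatter), so the large gaps to both remain. No measurement at hand accounts for this result. Going by these compounds, whether ethoxy, a longer chain or a carboxylic acid here stays at the low level of compound 3 and compound 4 or moves toward compound 1 and compound 2 remains open.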